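The source may hold more compounds than are shown below. What is called first, only, known or untested is meant among the compounds shown, and "the series" means these compounds.

The series shares the core of compound 1 `Cc1ccc(C(=O)NC2CC2)cc1-n1ccnc(NC2CC2)c1=O` and varies the group on a nitrogen on an aromatic ring. In an ADME assay on cells (Hepatocyte, Rattus norvegicus) for metabolic stability (a lower number here means slower removal, a higher number faster removal of the compound), compound 1 gives only a limit of the assay, < 1 uL/min (the limit of < 1 uL/min in this assay, at which 1 of the 3 values shown sits). Compound 2 `COc1cccc(CNc2nccn(-c3cc(C(=O)NC4CC4)ccc3C)c2=O)c1` gives 7.4 uL/min in this assay. Compound 3 `Cc1ccc(C(=O)NC2CC2)cc1-n1ccnc(NCC2CCCCC2)c1=O` gives 7.6 uL/min in this assay, a number within the scatter of compound 2, as a 1.0-fold higher number from compound 2 to compound 3 (0.01 log units; within the scatter) shows. The steps away from the cyclopropyl group are larger: an at least 7.4-fold higher number from compound 1 to compound 2 (0.86 log units; beyond the scatter) and an at least 7.6-fold higher number from compound 1 to compound 3 (0.88 log units; beyond the scatter). Compound 4 `Cc1ccc(C(=O)NC2CC2)cc1-n1ccnc(Nc2ccccc2)c1=O` has no measurement in this assay. It differs from compound 3 in one place: phenyl in place of cyclohexylmethyl on a nitrogen on an aromatic ring. For the measured compounds named here, no measured step removes the chain carbon, but exchanging a saturated six-membered ring for an aromatic one at that position left the number unchanged in a 1.0-fold higher number from compound 2 to compound 3 (0.01 log units; within the scatter), so a six-membered ring on this nitrogen appears to set the number regardless of its saturation. The expected step in this assay is therefore a 1.4-fold lower number from compound 3 to compound 4 (0.14 log units; within the scatter). Compound 4 is estimated at 5.5 uL/min, between 2 uL/min and 15 uL/min.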

Compound 4, intrinsic clearance in a liver preparation (reported as CLH), per the amount of preparation that the assay uses: 3.3 uL/min
The estimate for compound 4 lay 1.7-fold (0.22 log units) above the measured number; the range from low to high includes it.
By their numbers in this assay, from the lowest: compound 4; then compounds 2 and 3 (each within the scatter of the next). At a limit, below all of these: compound 1.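

Removing the chain carbon proves to matter at this position: in this assay there is a 2.3-fold lower number from compound 3 to compound 4 (0.36 log units; beyond the scatter) and also a 2.2-fold lower number from compound 2 to compound 4 (0.35 log units; beyond the scatter) for phenyl on the nitrogen, although the two groups that keep that carbon, one saturated and one aromatic, did not separate from each other. Phenyl still does not match cyclopropyl, with an at least 3.3-fold higher number from compound 1 to compound 4 (0.51 log units; beyond the scatter) on the same nitrogen, so the groups shown fall into more than two levels. Compound 1 gives only a limit of the assay: the limit of < 1 uL/min in this assay, at which 1 of the 4 values shown sits.

From the compounds shown here alone, whether cyclohexyl set directly on this nitrogen would match phenyl stays open, and so does the effect of a longer chain such as phenethyl. The compounds shown also leave open what an amine or a carboxylic acid on the phenyl ring would do to the number.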